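The source may hold more compounds than are shown below. What is called first, only, known or untested is meant among the compounds shown, and "the series" means these compounds.

For the measured compounds named here, compound 2 `O=C(CCc1ccccc1)N1CCC(O)(CN2C=Nc3cc(NCCN4CCCC4)ccc3C2O)CC1` gives 4860 nM in an assay on isolated protein for inhibition of ubiquitin carboxyl-terminal hydrolase 7 (Homo sapiens), read by TR-FRET, with stated times of 75 min and 1 h (on this read-out lower numbers stand for stronger inhibition and higher numbers for weaker inhibition), and stands with the lowest of the two numbers so far; its nearest neighbour is compound 1 `O=C(CCc1ccccc1)N1CCC(O)(CN2C=Nc3cc(NCCN4CCCCC4)ccc3C2O)CC1`, which gives 37000 nM in this assay, and the step of a 7.6-fold lower number from compound 1 to compound 2 (0.88 log units; beyond the scatter) separates the two. Compound 3 `O=C(CCc1ccccc1)N1CCC(O)(CN2C=Nc3cc(NCCO)ccc3C2O)CC1` differs from compound 2 by hydroxy in place of pyrrolidin-1-yl on a saturated chain carbon, two bonds along the chain from a nitrogen on an aromatic ring. Going by the values given here, only one measured step bears on this change: the step of a 7.6-fold lower number from compound 1 to compound 2 (0.88 log units; beyond the scatter) showed that altering the ring on that chain carbon moves the number well beyond the scatter, so the chain end is a sensitive position. Compound 3 goes further, leaving no ring at all, and nothing in the data says in which direction that should fall; the step from compound 2 to compound 3 is expected to be a 3.1-fold higher number from compound 2 to compound 3 (0.49 log units; beyond the scatter), with a broad range. Compound 3 is therefore estimated at 15000 nM in this assay, between 3000 nM and 60000 nM.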

Compound 3, half-maximal inhibitory concentration: 16400 nM
For compound 3 the middle estimate is 1.1-fold (0.04 log units) below the measured one; the measured number falls inside the stated range.
By their numbers in this assay, from the lowest: compound 2; then compound 3; then compound 1.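

In this assay, putting hydroxy in place of the ring gives a 3.4-fold higher number from compound 2 to compound 3 (0.53 log units; beyond the scatter) but a 2.3-fold lower number from compound 1 to compound 3 (0.35 log units; beyond the scatter) on the other side, so the same kind of change moves the number in opposite directions depending on which ring leaves. Among these three compounds, a ring on this chain carbon therefore does not by itself give the lower number: the pyrrolidin-1-yl of compound 2 stands below the hydroxy of compound 3, while the piperidin-1-yl of compound 1 stands above it. No available evidence explains this order. The compounds shown leave open how an open-chain amine such as dimethylamino, or a morpholin-4-yl ring, would stand against these three. They also leave open whether a carboxylic acid or a longer chain at this place would lower the number further.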